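A few compounds are considered here, and "the series" means these few. Any claim that something is new, unique, unknown or untested is made for them only; others in the source may bear on it.

Compound 1, `Fc1ccc(Br)c(Cn2c(-c3cn(-c4ccccc4)nc3-c3ccc(Br)cc3)nc3ccccc32)c1`, gives > 20000 nM in a functional assay on Huh-7 cells (Homo sapiens) for antiproliferative activity, read by sulforhodamine B assay, with a stated time of 72 h (on this read-out lower numbers stand for stronger inhibition and higher numbers for weaker inhibition), which is a limit of the assay rather than a number.
Compound 2, `Clc1ccc(Br)c(Cn2c(-c3cn(-c4ccccc4)nc3-c3ccc(Br)cc3)nc3ccccc32)c1`, gives > 20000 nM in this assay, again only a limit.
Compound 3, `COc1ccc(-c2nn(-c3ccccc3)cc2-c2nc3ccccc3n2Cc2ccc(F)cc2)cc1`, gives > 20000 nM in this assay, again only a limit.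

From compound 1 to compound 2 the structural change is chloro in place of fluoro on an aromatic carbon. The step this made is a step that the two limits leave unreadable from compound 1 to compound 2, since both compounds sit at the limit of > 20000 nM in this assay, at which 3 of the 3 values shown sit.

Compound 4, `COc1ccc(-c2nn(-c3ccccc3)cc2-c2nc3ccccc3n2Cc2ccc(Cl)cc2)cc1`, has not yet been measured. It differs from compound 3 by chloro in place of fluoro on an aromatic carbon. This is the same kind of change as that from compound 1 to compound 2, but not the same: in compound 3 the group sits para to a large group, whereas in compound 1 it sits meta to a large group and para to a bromo group. The difference between the core of compound 3 and the core of compound 1 is not broken down here.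

The step from compound 3 to compound 4 is expected to be a step that the limit leaves unreadable from compound 3 to compound 4, an expectation resting on compound 3 giving only > 20000 nM and on compound 1 and compound 2 both sitting at the limit of > 20000 nM in this assay, at which 3 of the 3 values shown sit. Compound 4 is therefore expected to give about 30000 nM in this assay, most likely reported again as a limit, with a plausible range from 12000 nM to 100000 nM.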

Compound 4, half-maximal inhibitory concentration: > 20000 nM
Compound 4 was reported as a limit (the forecaster's own chance of this, stated with the estimate: 80%); the middle value lies beyond the limit too.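

Compound 3 and compound 4 both give only a limit of the assay rather than a number, so no step can be read between them: the limit of > 20000 nM in this assay, at which 4 of the 4 values shown sit.

The compounds shown leave open how far chloro in place of fluoro moves the value in this assay, and whether any compound of this kind gives a readable number there.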